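The compounds below may be only part of what the source reports. "The series", "measured", "known", "first", "only" and "open" are said of these compounds alone.

Compounds 1 and 2 share one core and have both been tested in a functional assay on MOLT-4 cells (Homo sapiens) for inhibition, read by sulforhodamine B assay, with a stated time of 48 h; a higher number here means that more compound is tolerated, a lower number that less compound is tolerated. For compound 1 `COc1cc(-c2nn(-c3cccc(NC(=O)Nc4cc(C(F)(F)F)cc(C(F)(F)F)c4)c3)cc2-c2ccncc2)ccc1Cl` this assay reports only a limit, > 50000 nM. For compound 2 `COc1cc(-c2nn(-c3cccc(NC(=O)c4cccc(C(F)(F)F)c4)c3)cc2-c2ccncc2)ccc1Cl` this assay likewise reports only a limit, > 50000 nM. Going by the values given here, neither value is a number: both sit at the limit of > 50000 nM in this assay, at which 2 of the 2 values shown sit, so no step between the two can be sized, and compound 2 stands at the edge of what the assay can report rather than at a measured point. Compound 3 `COc1cc(-c2nn(-c3cccc(NC(=O)c4ccc(Cl)c(C(F)(F)F)c4)c3)cc2-c2ccncc2)ccc1Cl` differs from compound 2 in one place: chloro in place of hydrogen on an aromatic carbon. Among the compounds with values here, compound 2 is known only by a limit, so no measured step offers a guide to the size of this change. The expectation is that the step that the limit leaves unreadable from compound 2 to compound 3 in this assay stays within the scatter, leaving compound 3 at or beyond the same limit. Compound 3 is therefore estimated at 60000 nM, with a range from 30000 nM to 150000 nM.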

Compound 3, concentration lethal to 50% of the cells: > 32500 nM
Compound 3 ended at the assay's limit; the forecaster's own chance of this, stated with the estimate: 80%; the middle value does not contradict the limit.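

Going by these compounds alone, compound 2 and compound 3 are each known only by a limit in this assay, so no step between them can be read. The compounds shown leave open how large the change from hydrogen to chloro is, and where any of these compounds would give an actual number.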